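Agonist series: 1-methyl-1H-pyrazol-3-yl in place of 1,3-thiazol-2-yl

The compounds below may be only part of what the source reports. "The series", "measured", "known", "first", "only" and "open" are said of these compounds alone.

Measured in a functional assay on CHO cells for agonist activity at Alpha-1B adrenergic receptor (Homo sapiens), read by FLIPR and calcium flux; a higher number here means that more compound is needed for the effect, a lower number that less compound is needed:
compound 1 `c1cc(-c2nccs2)c2c(c1)C(c1ncc[nH]1)CC2` — > 10000 nM
compound 2 `Cc1c(OCC2=NCCN2)ccc(Cl)c1NS(C)(=O)=O` — > 10000 nM
compound 3 `c1ccc2c(c1)CCC2c1ncc[nH]1` — > 10000 nM

Each of these three values is a limit of the assay, not a number. Compound 1 stands at that limit, (the limit of > 10000 nM in this assay, at which 3 of the 3 values shown sit), so its position among the measured compounds cannot be ranked. Among the measured compounds shown here, the one single-point step among them, a step that the two limits leave unreadable from compound 1 to compound 3, is left unreadable by the two limits, and compound 2 belongs to a different core, so it gives no step to compound 1.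

The next compound, compound 4 `Cn1ccc(-c2cccc3c2CCC3c2ncc[nH]2)n1`, differs from compound 1 by 1-methyl-1H-pyrazol-3-yl in place of 1,3-thiazol-2-yl on an aromatic carbon. For the measured compounds named here, no measured step bears readably on this change; the only step in the set, from compound 1 to compound 3, is unreadable. Expectation therefore rests on compound 1 alone, which in this assay sits at the limit > 10000 nM.

For compound 4 the expected step from compound 1 is a step that the limit leaves unreadable from compound 1 to compound 4, i.e. no readable change. Compound 4 is estimated at 20000 nM, within 8000 nM to 100000 nM, and most probably the assay will again report only a limit.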

Compound 4, half-maximal effective concentration: > 10000 nM
Compound 4 ended at the assay's limit; the forecaster's own chance of this, stated with the estimate: 85%; the middle value does not contradict the limit.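

In this assay compound 4 gives > 10000 nM as a limit and not a number, and the steps to it from compound 1 and compound 3 cannot be read. The compounds shown leave open at what concentration, if any, each would act as an agonist: the limit of > 10000 nM in this assay, at which 4 of the 4 values shown sit.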